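Toward a methoxymethyl ether on the shared core

The compounds below may be only part of what the source reports. "The series", "measured", "known", "first", "only" and "open" are said of these compounds alone.

Measured compounds:
compound 1 `CO[C@H]1CC=C2CCN(C)[C@H]2C1`: 100000 nM
compound 2 `CN1CCC2=CC[C@H](OCc3ccccc3)C[C@@H]21`: 300000 nM

In an assay on HEK293 cells for displacement of a labelled ligand from Neuronal acetylcholine receptor; alpha3/beta4 (Rattus norvegicus), with a stated time of 4 h (a lower number here means a stronger inhibitor, a higher number a weaker inhibitor), compound 2 gives 300000 nM, the highest of the two numbers; the nearest is compound 1, which gives 100000 nM. Compound 3 `COCCO[C@H]1CC=C2CCN(C)[C@H]2C1` differs from compound 2 by methoxymethyl in place of phenyl on a saturated chain carbon bound to an oxygen on a saturated carbon. Among the compounds with values here, the only step that bears on this is a 3.0-fold higher number from compound 1 to compound 2 (0.48 log units; beyond the scatter), where phenyl entered; here phenyl leaves again and a smaller group enters. Compound 3 is therefore expected to move back toward compound 1, with a step of a 2.0-fold lower number from compound 2 to compound 3 (0.30 log units; within the scatter). The estimate for compound 3 in this assay is 150000 nM, within 50000 nM to 500000 nM.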

Compound 3, inhibition constant: > 300000 nM
Compound 3: only a limit was reported; the forecaster's own chance of this, stated with the estimate: 30%; at least 2.0-fold (0.30 log units) between middle value and limit.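

In this assay compound 3 gives only a limit, not a number, > 300000 nM. With methoxymethyl in place of hydrogen, the data show an at least 3.0-fold higher number from compound 1 to compound 3 (0.47 log units; beyond the scatter), so at this place a group without a ring, like phenyl, does not return the number to that of compound 1. With methoxymethyl in place of phenyl, the data show a number no lower from compound 2 to compound 3 (the limit leaves the size open). As far as these compounds go, whether an amine or a carboxylic acid in the same place would lower the number remains open.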